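The compounds below may be only part of what the source reports. "The series", "measured", "known", "first", "only" and "open" are said of these compounds alone.

Series notes, values from an ADME assay on MT4 cells (Homo sapiens) for cytotoxicity, read by MTT assay; on this read-out higher numbers stand for lower toxicity in this test and lower numbers for higher toxicity in this test:

- Compound 1 `O=C(CSc1nc(Cc2c(Cl)cccc2Cl)cc(=O)[nH]1)c1ccccc1`: > 12000 nM, a limit
- Compound 2 `CCc1c(Cc2c(Cl)cccc2Cl)nc(SCC(=O)c2ccccc2)[nH]c1=O`: > 52000 nM, a limit
- Compound 3 `CCc1c(Cc2c(Cl)cccc2Cl)nc(SCC(=O)c2ccc(OC)cc2)[nH]c1=O`: > 54000 nM, a limit

For the measured compounds named here, no measured compound has an exact number so far. Compound 2 stands only at a limit, > 52000 nM. It therefore gives a reference point for the next comparison, not a true value.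

The next compound is compound 4 `CCc1c(Cc2c(F)cccc2F)nc(SCC(=O)c2ccccc2)[nH]c1=O`, which carries 2,6-difluorophenyl in place of 2,6-dichlorophenyl on a saturated chain carbon bound to an aromatic carbon. Two measured steps lie nearest to this change, though neither touches that place. One is a step that the two limits leave unreadable from compound 1 to compound 2, with ethyl in place of hydrogen on an aromatic carbon. The other is a step that the two limits leave unreadable from compound 2 to compound 3, with methoxy in place of hydrogen on an aromatic carbon. Neither has a readable size, so the series offers no measured effect to carry over, and no direction can be drawn from them.

In this assay, the working expectation is no change beyond the scatter, and another limit is the likeliest report. The expected move is a step that the limit leaves unreadable from compound 2 to compound 4. Compound 4 is estimated at 60000 nM, with an expected range from 20000 nM to 200000 nM.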

Compound 4, half-maximal cytotoxic concentration: 56000 nM
Compound 4: the middle estimate sits 1.1-fold (0.03 log units) above what was measured; the range from low to high includes it.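

No new step can be read from this result: compound 2 stands only as a limit in this assay, so the comparison with compound 4 has no readable size. The compounds shown leave open what 2,6-difluorophenyl in place of 2,6-dichlorophenyl does to the value in this assay, whether a change or none.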